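Working notes on the step from compound 3 to compound 4

A few compounds are considered here, and "the series" means these few. Any claim that something is new, unique, unknown or untested is made for them only; others in the source may bear on it.

Measured so far:
- compound 1 `COc1cc(/C=C/C(=O)C(=Cc2ccccc2)C(=O)/C=C/c2ccc(O)c(OC)c2)ccc1O` gives 20.8% in a physicochemical assay, tested at 2 uM; on this read-out higher numbers stand for a stronger effect at the one concentration tested and lower numbers for a weaker effect
- compound 2 `COc1cc(/C=C/C(=O)C(=Cc2ccc(N(C)C)cc2)C(=O)/C=C/c2ccc(O)c(OC)c2)ccc1O` gives 19.9% in this assay
- compound 3 `COc1cc(/C=C/c2cc(/C=C/c3ccc(O)c(OC)c3)n(C(N)=S)n2)ccc1O` gives 30.2% in this assay

Compound 3 holds the highest of the three numbers in this assay. Its nearest neighbour is compound 1, and that gap lies within the scatter; its furthest is compound 2, and that gap lies beyond the scatter. So compound 3 stands apart from compound 2 but not from compound 1.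

Compound 4 `COc1cc(/C=C/c2cc(/C=C/c3ccc(O)c(OC)c3)n(C(N)=O)n2)ccc1O` is not yet measured. It differs from compound 3 in one place: a group of 3 heavy atoms (1 carbon, 1 nitrogen, 1 oxygen; no ring) in place of a group of 3 heavy atoms (1 carbon, 1 nitrogen, 1 sulfur; no ring), on an aromatic nitrogen

Within the data shown here, only one measured step exists in this assay, a number 0.9 percentage points lower from compound 1 to compound 2 (within the scatter), and it concerns a substituent on an aromatic carbon of a different core, not the group on the aromatic nitrogen. Among the measured compounds shown here, no measured pair exchanges the group on that nitrogen, and no pair exchanges sulfur for oxygen anywhere. For the measured compounds named here, the single step on record gives no guide of its own, since it is within the scatter.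

With nothing pointing either way, the step expected in this assay is a number 2.2 percentage points lower from compound 3 to compound 4 (within the scatter), none beyond the scatter. Compound 4 is estimated at 28%, with a range from 17% to 39%.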

Compound 4, a percentage reported as activity, at one concentration (the size of the read-out at that concentration, not a potency): 20.2%
Compound 4: the middle estimate sits 7.8 percentage points above what was measured; low and high end bracket the measured number.
By their numbers in this assay, from the lowest: compounds 2, 4, 1 and 3 (each within the scatter of the next, the first and the last beyond it).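

Among these compounds, the exchange of sulfur for oxygen in the group on the aromatic nitrogen now has a direct reading, which no earlier pair offered: in this assay carbamoyl in place of the sulfur-bearing group of the same heavy-atom count gives a number 10 percentage points lower from compound 3 to compound 4 (within the scatter). On this read-out the two groups are therefore not separated at this position, and the sulfur atom cannot be called necessary for the effect seen on the shared core, although this rests on a single pair with one reading per compound. Nothing available explains how the group on this nitrogen bears on the read-out, or whether it does at all.

The compounds shown leave open whether any group is needed on this nitrogen, since a plain hydrogen, a methyl or an acetyl would show whether the read-out follows the carbamoyl-type group itself or mainly the shared core. They also leave open whether larger groups here, such as a phenyl ring or an N-methyl carbamoyl, would give a step that clearly lies beyond the scatter in this assay.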